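The compounds below may be only part of what the source reports. "The series", "measured", "known", "first", "only" and "open" are said of these compounds alone.

Compound 1, `C=CC(=O)Nc1cccc(NC(=O)CSc2nc(Nc3cccc(OC)c3)c3ccccc3n2)c1`: 7940 nM
Compound 2, `C=CC(=O)Nc1cccc(NC(=O)CSc2nc(Nc3ccc(Cl)cc3)c3ccccc3n2)c1`: 7580 nM

Both compounds were tested in a functional assay on NCI-H1975 cells (Homo sapiens) for inhibition, read by MTT assay, with a stated time of 72 h; a lower number here means a stronger inhibitor, a higher number a weaker inhibitor. Going by the values given here, compound 2 has the lowest of the two numbers, but the only measured step, a 1.0-fold lower number from compound 1 to compound 2 (0.02 log units; within the scatter), is within the scatter, so the two compounds cannot be told apart on these data.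

Compound 3, `C=CC(=O)Nc1cccc(NC(=O)CSc2nc(Nc3ccc(Br)cc3)c3ccccc3n2)c1`, differs from compound 2 by bromo in place of chloro on an aromatic carbon. Among the compounds with values here, the one measured step bears on it only loosely: it exchanged one whole aryl group for another and still left the number unchanged, whereas the change to compound 3 is smaller, one halogen for another on the same ring. Nothing here points to a shift in either direction, so the expectation is a step of a 1.1-fold lower number from compound 2 to compound 3 (0.03 log units; within the scatter), within the scatter. Compound 3 is estimated at 7000 nM in this assay, with a range from 3000 nM to 16000 nM.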

Compound 3, half-maximal inhibitory concentration: 6280 nM
The estimate for compound 3 lay 1.1-fold (0.05 log units) above the measured number, within the range that was stated.
By their numbers in this assay, from the lowest: compounds 3, 2 and 1 (each within the scatter of the next).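

Swapping one halogen for the next (a 1.2-fold lower number from compound 2 to compound 3 (0.08 log units; within the scatter)) gives the first direct look at this place on the ring, para to a large group, and in this assay chloro and bromo cannot be told apart there. The wider exchange of 3-methoxyphenyl for 4-bromophenyl (a 1.3-fold lower number from compound 1 to compound 3 (0.10 log units; within the scatter)) also stays within the scatter, so three different aryl groups on this nitrogen now read alike, where the earlier pair covered only two. Nothing available here explains this sameness.

On these data alone, whether any group at this place can move the number at all remains open: an amine, a carboxylic acid or a longer chain such as butyl could each be set against chloro and bromo. Also open, as far as these compounds go, is whether a change elsewhere on the shared core would matter more than one on this ring.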